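Replacing a methoxymethyl chain with hydrogen: an expected half-life

This account rests on a few compounds, and the source may have more. Where it says the series, first, only, none or still open, it means among the compounds named here.

Compound 3 `COCCc1sc(N(CC2CC2)[C@H](C)c2ccc(-c3cc(C)ccc3-c3nc(=O)o[nH]3)cc2)nc1C(=O)NS(=O)(=O)C1CC1` stands second highest of the three numbers measured in an ADME assay on the whole organism (Macaca fascicularis) for metabolic stability (on this read-out higher numbers stand for a longer-lived compound and lower numbers for a shorter-lived compound), where compound 3 gives 2.6 h. Its nearest neighbour is compound 2 `Cc1ccc(-c2nc(=O)o[nH]2)c(-c2ccc([C@@H](C)N(CC3CC3)c3nc(C(=O)NS(=O)(=O)C4CC4)c(C4CCC4)s3)cc2)c1`, which gives 2.8 h in this assay, and a 1.1-fold lower number from compound 2 to compound 3 (0.03 log units; within the scatter). Compound 1 `Cc1ccc(-c2nc(=O)o[nH]2)c(-c2ccc([C@@H](C)N(CC3CC3)c3nc(C(=O)NS(=O)(=O)C4CC4)c(CC(C)C)s3)cc2)c1` gives 2.3 h in this assay; a 1.2-fold higher number from compound 1 to compound 2 (0.09 log units; within the scatter), and a 1.1-fold higher number from compound 1 to compound 3 (0.05 log units; within the scatter), the exchange that introduced the methoxymethyl group carried by compound 3.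

Compound 4 `Cc1ccc(-c2nc(=O)o[nH]2)c(-c2ccc([C@@H](C)N(CC3CC3)c3nc(C(=O)NS(=O)(=O)C4CC4)c(C)s3)cc2)c1` differs from compound 3 in one place: hydrogen in place of methoxymethyl on a saturated chain carbon bound to an aromatic carbon. For the measured compounds named here, no measured step covers this exact exchange, but all three measured steps alter the same position of the shared core, and every one of them stayed within the scatter, the largest being the one from compound 1 to compound 2. On that basis the step from compound 3 to compound 4 in this assay is expected to be a 1.0-fold lower number from compound 3 to compound 4 (0.02 log units; within the scatter), nothing beyond the scatter in either direction. Compound 4 is therefore estimated at 2.5 h in this assay, with a range from 1.4 h to 4.5 h.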

Compound 4, half-life: 2.1 h
For compound 4 the middle estimate is 1.2-fold (0.08 log units) above the measured one; low and high end bracket the measured number.
By their numbers in this assay, from the lowest: compounds 4, 1, 3 and 2 (each within the scatter of the next).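

Whichever group it replaces, methyl on this aromatic carbon stays within the scatter in this assay: a 1.2-fold lower number from compound 3 to compound 4 (0.09 log units; within the scatter) when the methoxymethyl part leaves, a 1.1-fold lower number from compound 1 to compound 4 (0.04 log units; within the scatter) when the isopropyl part leaves, and a 1.3-fold lower number from compound 2 to compound 4 (0.12 log units; within the scatter) when cyclobutyl leaves. The earlier compounds shown here compared only isobutyl, cyclobutyl and 2-methoxyethyl with one another, whereas compound 4 shows that cutting the substituent back to methyl also leaves the half-life within the scatter. Across compounds 1, 2, 3 and 4, no step at this position goes beyond the scatter, and no compound goes against this.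

No available data bear on why the half-life stays within the scatter across these groups. Going by these compounds, whether an amine, a carboxylic acid or a longer chain at this position would go beyond the scatter remains open.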